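Replacing hydroxy with cyanomethyl: notes on tolerated concentration

The compounds below may be only part of what the source reports. "The series", "measured", "known", "first", "only" and "open" are said of these compounds alone.

Measured in an ADME assay on HEp-2 cells (Homo sapiens) for cytotoxicity; a higher number here means that more compound is tolerated, a lower number that less compound is tolerated:
Compound 1 `C=C(C)n1c(=O)n(Cc2nc3ccccc3n2CCC(C)C)c2ccccc21`: 24600 nM
Compound 2 `CC(C)CCn1c(Cn2c(=O)n(C(C)C)c3ccccc32)nc2c(CO)cccc21`: 22000 nM

Compound 2, at 22000 nM, lies within the usual scatter of compound 1, at 24600 nM, so the two numbers cannot be ranked against each other.

Compound 3 `CC(C)CCn1c(Cn2c(=O)n(C(C)C)c3ccccc32)nc2c(CCC#N)cccc21` has not yet been measured. It differs from compound 2 by cyanomethyl in place of hydroxy on a saturated chain carbon bound to an aromatic carbon. Read one bond further out, this is hydroxymethyl to 2-cyanoethyl.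

Going by the values given here, no measured pair differing in one place is available as a guide. No shift beyond the scatter, in either direction, is therefore expected in this assay. The expected change is a 1.1-fold lower number from compound 2 to compound 3 (0.04 log units; within the scatter). The estimated value for compound 3 is 20000 nM, with a range of 8000 nM to 50000 nM.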

Compound 3, half-maximal cytotoxic concentration: 2240 nM
Beside the measured number, compound 3's estimate is 8.9-fold (0.95 log units) above it; measured number outside the range, below it.
By their numbers in this assay, from the lowest: compound 3; then compounds 2 and 1 (each within the scatter of the next).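

In this assay, going by these compounds alone, the place on a saturated chain carbon bound to an aromatic carbon proves sensitive: cyanomethyl in place of hydroxy gives a 9.8-fold lower number from compound 2 to compound 3 (0.99 log units; beyond the scatter) and is the only single-place step available. Compound 1 and compound 2 offered no such reading of this place, since they differ in more than one place. The change removes a hydrogen-bond donor and brings in a triple bond, but no available data bear on what lies behind the shift.

From the compounds shown here alone, whether the loss of the hydroxy or the arrival of the nitrile carries the step remains open. An amine, a carboxylic acid or a longer chain ending in a nitrile at this place would show how far the tolerated concentration follows the group.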